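Swapping the Side Chain at the Aromatic Nitrogen

The source may hold more compounds than are shown below. What is called first, only, known or untested is meant among the compounds shown, and "the series" means these compounds.

Measured compounds:
compound 1 `CCCn1c(=O)n(C2OC(COP(=O)(O)O)[C@@H](O)[C@H]2O)c2nc(N)nc(O)c21` gives 76%
compound 2 `Nc1nc(O)c2c(n1)n(C1OC(CO)[C@@H](O)[C@H]1O)c(=O)n2CC(O)CSc1ccccc1` gives 12%

Among the measured compounds shown here, in a functional assay on the whole organism (B cells) with Mus musculus as the target (a higher number here means a larger maximal response, a lower number a smaller maximal response), compound 2 stands lowest of the two numbers; its only neighbour, compound 1, lies far above it, a gap beyond the usual scatter. Compound 3 `N#Cc1cccc(Cn2c(=O)n(C3OC(CO)[C@@H](O)[C@H]3O)c3nc(N)nc(O)c32)c1` is not yet measured. It differs from compound 2 in one place: 3-cyanophenyl in place of 1-hydroxy-2-(phenylsulfanyl)ethyl on a saturated chain carbon bound to an aromatic nitrogen. For the measured compounds named here, no measured pair differs in this way alone, so the size of the step is open. The step expected is a number 18 percentage points higher from compound 2 to compound 3 (beyond the scatter), a moderate rise with wide uncertainty. Compound 3 is estimated at 30%, within 8% to 65%.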

Compound 3, largest response reached (reported as maximal response), in percent of the reference or control that the assay uses: 16%
For compound 3 the middle estimate is 14 percentage points above the measured one; the measured number falls inside the stated range.
By their numbers in this assay, from the lowest: compounds 2 and 3 (each within the scatter of the next); then compound 1.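

In this assay, putting 3-cyanophenyl in place of 1-hydroxy-2-(phenylsulfanyl)ethyl on a saturated chain carbon bound to an aromatic nitrogen gives a number 4 percentage points higher from compound 2 to compound 3 (within the scatter). At this position, therefore, the loss of the sulfur and the hydrogen-bond donor leaves the read-out indistinguishable from that of the longer group. No supporting data explain this result.

As far as these compounds go, compound 1 differs from both in more than one place, so how much of its response belongs to this position stays open. Also open, from the compounds shown here alone, is how an amine or a carboxylic acid on the phenyl ring would read.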